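A few compounds are considered here, and "the series" means these few. Any claim that something is new, unique, unknown or untested is made for them only; others in the source may bear on it.

In a functional assay on HeLa cells (Homo sapiens) for antiproliferative activity, read by MTT assay, with a stated time of 24 h (a lower number here means a stronger inhibitor, a higher number a weaker inhibitor), compound 1 `COc1ccc(S(=O)(=O)n2c(-c3cn(-c4ccccc4)nc3-c3ccc(F)cc3)nc3ccccc32)cc1` gives 390 nM and shares the stronger end of this small set with compound 2 `Cc1ccc(C)c(S(=O)(=O)n2c(-c3cn(-c4ccccc4)nc3-c3ccc(F)cc3)nc3ccccc32)c1` at 320 nM since the gap is a 1.2-fold lower number from compound 1 to compound 2 (0.09 log units; within the scatter) only. Compound 3 `O=S(=O)(c1ccc(Cl)cc1)n1c(-c2cn(-c3ccccc3)nc2-c2ccc(F)cc2)nc2ccccc21` is the weakest at 3450 nM with an 8.8-fold higher number from compound 1 to compound 3 (0.95 log units; beyond the scatter) and an 11-fold higher number from compound 2 to compound 3 (1.03 log units; beyond the scatter) in the two comparisons. Compound 4 `COc1ccc(S(=O)(=O)n2c(-c3cn(-c4ccccc4)nc3-c3ccc(C(F)(F)F)cc3)nc3ccccc32)cc1` differs from compound 1 in one place: trifluoromethyl in place of fluoro on an aromatic carbon. For the measured compounds named here, no measured step touches that group, since all three changed the sulfonyl aryl group instead. Going by the values given here, they show only that a single swap elsewhere can shift the number, as in an 8.8-fold higher number from compound 1 to compound 3 (0.95 log units; beyond the scatter) for the chloro compound. A small rise is therefore expected, read as a 1.5-fold higher number from compound 1 to compound 4 (0.19 log units; within the scatter) with wide uncertainty. Compound 4 is estimated at 600 nM with an expected range from 200 nM to 2000 nM in this assay for now.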

Compound 4, half-maximal inhibitory concentration: 250 nM
Estimate against measurement, compound 4: 2.4-fold (0.38 log units) above; low and high end bracket the measured number.
By their numbers in this assay, from the lowest: compounds 4, 2 and 1 (each within the scatter of the next); then compound 3.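

On an aromatic carbon para to a large group, 4-fluorophenyl gives way to 4-(trifluoromethyl)phenyl with a 1.6-fold lower number from compound 1 to compound 4 (0.19 log units; within the scatter) in this assay. This is the first step shown at this position, and going from 1 heavy atom to 4 leaves the number within the scatter, whereas the sulfonyl aryl group has already produced a step beyond it. Nothing measured here accounts for this result. Going by these compounds, whether an amine or a carboxylic acid would be accepted at this position remains open. So does whether trifluoromethyl would read the same alongside the 4-chlorophenyl group of compound 3.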